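Series notes: varying the aniline substituent on the shared core

The compounds below may be only part of what the source reports. "The series", "measured", "known", "first", "only" and "open" are said of these compounds alone.

Two compounds of the shared core carry a measured number. Compound 1 `COC(=O)c1ccc(NC2=CC(=O)c3ncncc3C2=O)cc1` gives 1100 nM in a functional assay on PANC-1 cells (Homo sapiens) for cytotoxicity, read by MTT assay, with a stated time of 72 h; a higher number here means a weaker inhibitor, a lower number a stronger inhibitor. Compound 2 `CCc1ccc(-c2ccc(NC3=CC(=O)c4ncncc4C3=O)cc2)cc1` gives 1200 nM in this assay. The step of a 1.1-fold higher number from compound 1 to compound 2 (0.04 log units; within the scatter) shows that exchanging the group on the aromatic carbon of the aniline ring changes the number little. Compound 2 stands highest of the two numbers, but its nearest neighbour, compound 1, lies within the scatter of it, so no order between the two can be read.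

The next compound, compound 3 `O=C1C(Nc2ccc(Oc3ccccc3)cc2)=CC(=O)c2ncncc21`, differs from compound 2 by phenoxy in place of 4-ethylphenyl on an aromatic carbon. Going by the values given here, the one step that bears on this change, a 1.1-fold higher number from compound 1 to compound 2 (0.04 log units; within the scatter), replaced one group at the same place by another without moving the number beyond the scatter. Among the compounds with values here, no further step at this position is known, so the expectation rests on that single comparison.

For compound 3 the estimated step of a 1.1-fold lower number from compound 2 to compound 3 (0.04 log units; within the scatter) is expected to stay within the scatter. Compound 3 is therefore expected to give 1100 nM in this assay, with a range of 400 nM to 3000 nM.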

Compound 3, half-maximal inhibitory concentration: 1800 nM
Beside the measured number, compound 3's estimate is 1.6-fold (0.21 log units) below it, and the stated range covers the measured number.
By their numbers in this assay, from the lowest: compounds 1, 2 and 3 (each within the scatter of the next).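

In this assay a third group at this aromatic carbon again leaves the number within the scatter: phenoxy in place of 4-ethylphenyl gives a 1.5-fold higher number from compound 2 to compound 3 (0.18 log units; within the scatter) and phenoxy in place of methoxycarbonyl gives a 1.6-fold higher number from compound 1 to compound 3 (0.21 log units; within the scatter) as the second reading for the new group. Methoxycarbonyl, 4-ethylphenyl and phenoxy can now be compared in every pairing, and none of the three steps leaves the scatter, so among these three groups the position shows no order, and the earlier single comparison no longer stands alone. The exchange of the carbon-only 4-ethylphenyl for phenoxy, which holds an oxygen and counts a hydrogen-bond acceptor, also stays within the scatter, and no measurement at hand bears on what lies behind these numbers.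

As far as these compounds go, whether an amine, a carboxylic acid or a longer alkyl chain at this place would move the number beyond the scatter remains open. Also open, from the compounds shown here alone, is whether the flat picture across these three groups holds when the substituent sits elsewhere on the aromatic ring or when the shared core itself is changed.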